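Shifting a nitrophenyl group: expected cytotoxicity of compound 4

The source may report more compounds than this note shows. Statements on the series, on what has been measured and on what is new or still open speak of the compounds shown alone.

Compound 1 `C#CCOc1ccc2ncnc(N3CCN(C)CC3)c2c1` is the simplest member of the set. In a functional assay on HepG2 cells (Homo sapiens) for cytotoxicity, read by MTT assay (a higher number here means a weaker inhibitor, a lower number a stronger inhibitor), compound 1 gives only a limit, > 200000 nM. Compound 2 `O=[N+]([O-])c1cccc(Nc2ncnc3ccc(OCc4cn(-c5ccccc5[N+](=O)[O-])nn4)cc23)c1` also reaches only a limit in this assay, > 200000 nM. Compound 3 `O=[N+]([O-])c1ccccc1-n1cc(COc2ccc3ncnc(NCc4ccccc4)c3c2)nn1` likewise sits at a limit, > 200000 nM. Within the data shown here, the one measured step, a step that the two limits leave unreadable from compound 2 to compound 3, cannot be read because the limit of > 200000 nM in this assay, at which 3 of the 3 values shown sit, covers every value shown. Compound 4 `O=[N+]([O-])c1cccc(-n2cc(COc3ccc4ncnc(NCc5ccccc5)c4c3)nn2)c1` differs from compound 3 by 3-nitrophenyl in place of 2-nitrophenyl on an aromatic nitrogen. Among the measured compounds shown here, no measured step bears on this change, and nothing departs from the limit, so no shift beyond the scatter is expected. Compound 4 is therefore expected to give about 300000 nM, within 100000 nM to 1000000 nM, most likely again only a limit. The expected step is a step that the limit leaves unreadable from compound 3 to compound 4.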

Compound 4, half-maximal inhibitory concentration: 94100 nM
Compound 4: middle estimate off by 3.2-fold (0.50 log units), on the high side, outside the stated range (below it).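

In this assay, 3-nitrophenyl in place of 2-nitrophenyl on an aromatic nitrogen gives an at least 2.1-fold lower number from compound 3 to compound 4 (0.32 log units; beyond the scatter), with the same atoms joined differently. Among these compounds, the series is therefore sensitive to where the nitro group sits on this phenyl ring, which the earlier compounds could not show. Compound 4 is the only compound shown that comes off the limit: the limit of > 200000 nM in this assay, at which 3 of the 4 values shown sit.

Going by these compounds, the full size of the step stays open, with only a limit for compound 3. Also open, on these data alone, is whether an amine or a carboxylic acid in place of the nitro group on this phenyl ring would keep the number seen for compound 4.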